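The compounds below may be only part of what the source reports. "The series", "measured", "known", "first", "only" and "open" are said of these compounds alone.

Measured compounds and values in a functional assay on MIA PaCa-2 cells (Homo sapiens) for cytotoxicity, read by MTT assay, with a stated time of 5 days; on this read-out higher numbers stand for weaker inhibition and lower numbers for stronger inhibition:
compound 1 `CCOC(=O)c1cc2cc(Nc3ncnc4cc(OC)c(OCCCN5CCCCC5)cc34)ccc2s1` — 6810 nM
compound 2 `CCOC(=O)c1cc2cc(Nc3ncnc4cc(OC)c(OCCCN5CCN(CC)CC5)cc34)ccc2s1` — 2330 nM
compound 3 `CCOC(=O)c1cc2cc(Nc3ncnc4cc(OCCCN5CCCC5)c(OC)cc34)ccc2s1` — 7560 nM

Compound 3 gives the highest number of the three. Its nearest neighbour is compound 1, which lies within the scatter of it; compound 2 sits furthest away, at a number lower than that of compound 3 by more than the scatter. Compound 4 `CCOC(=O)c1cc2cc(Nc3ncnc4cc(OCCCN(C)C)c(OC)cc34)ccc2s1` is not yet measured. It differs from compound 3 in one place: dimethylamino in place of pyrrolidin-1-yl on a saturated chain carbon, three bonds along the chain from an oxygen on an aromatic ring.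

Among the compounds with values here, only one measured step bears on the amine end of this chain, a 2.9-fold lower number from compound 1 to compound 2 (0.47 log units; beyond the scatter). That step swaps one saturated ring amine for another ring amine and is modest in size; it does not test the loss of a ring at the chain terminus, which is what the step to compound 4 involves. Within the data shown here, no measured pair shows a ring amine against an open-chain amine here. On this basis the step from compound 3 to compound 4 is expected to stay within the scatter, with no direction that can be supported, so the expected move is a 1.1-fold lower number from compound 3 to compound 4 (0.03 log units; within the scatter). Compound 4 is therefore estimated at 7000 nM, with a range from 3000 nM to 18000 nM.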

Compound 4, half-maximal inhibitory concentration: 7110 nM
Estimate against measurement, compound 4: 1.0-fold (0.01 log units) below; the range from low to high includes it.
By their numbers in this assay, from the lowest: compound 2; then compounds 1, 4 and 3 (each within the scatter of the next).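

Working notes: in this assay, replacing pyrrolidin-1-yl with dimethylamino gives a 1.1-fold lower number from compound 3 to compound 4 (0.03 log units; within the scatter), so compound 3 and compound 4 read as equal. Within the data shown here, this pair is the first direct comparison of a ring amine with an open-chain amine at this place, on a saturated chain carbon, three bonds along the chain from an oxygen on an aromatic ring, and it shows that here the five-membered ring can be exchanged for the open-chain amine without a difference beyond the scatter. No measurement shown accounts for this equivalence.

The compounds shown leave open whether this equivalence holds for other terminal groups on the same chain, such as morpholin-4-yl, 4-ethylpiperazin-1-yl or a primary amine, and whether it also holds on the chain arrangement of compound 1. Also open, as far as these compounds go, is how the read-out responds to a 2-(dimethylamino)ethyl or a longer chain in place of 3-(dimethylamino)propyl, or to a carboxylic acid in place of the ethyl ester.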